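Ether substituent change in an antagonist series

The source may hold more compounds than are shown below. What is called first, only, known or untested is meant among the compounds shown, and "the series" means these compounds.

Measured so far:
compound 1 `O=S1(=O)c2ccccc2CN1c1cc(F)cc(OCc2ccccc2)c1`: 36%
compound 2 `O=C1c2ccccc2C(=O)N1c1cc(F)cc(Oc2cccnc2)c1`: "not determined" (no result reported)

Going by the values given here, compound 1 holds the only number in a functional assay on Flp-In T-REx293 cells for antagonist activity at Free fatty acid receptor 1 (Homo sapiens), read by calcium flux; a lower number here means a smaller maximal response, a higher number a larger maximal response; compound 2 has no result there, so compound 1 stands alone without a comparison. Compound 3 `N#Cc1ccc(Oc2cc(F)cc(N3Cc4ccccc4S3(=O)=O)c2)cc1` differs from compound 1 in one place: 4-cyanophenyl in place of benzyl on an oxygen on an aromatic ring. Among the compounds with values here, no step between measured compounds is known, so the size of this change cannot be read from the data. The expected step is small, within or just beyond the scatter, with no firm direction: a number 4 percentage points higher from compound 1 to compound 3 (within the scatter). For compound 3 the estimate in this assay is 40%, from 20% to 65%.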

Compound 3, largest response reached (reported as Imax), in percent of the reference or control that the assay uses: 43%
Compound 3: middle estimate off by 3 percentage points, on the low side; the measured number falls inside the stated range.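

Exchanging benzyl for 4-cyanophenyl on the oxygen gives a number 7 percentage points higher from compound 1 to compound 3 (within the scatter) in this assay. On this single pair, the position accepts benzyloxy to 4-cyanophenoxy with no change in maximal response beyond the scatter. No measured evidence bears on this result.

Steps involving compound 2 cannot be read, as it has no value. Still open, going by these compounds, is whether a different group on this oxygen, such as a carboxylic acid, an amine or a longer alkyl chain, would move the response beyond the scatter.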